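The source may hold more compounds than are shown below. What is called first, only, known or untested is meant among the compounds shown, and "the series" means these compounds.

Working notes on the series, values in a functional assay on HeLa cells (Homo sapiens) for antiproliferative activity, with a stated time of 5 days; a lower number here means a stronger inhibitor, a higher number a weaker inhibitor:

- compound 1 `COc1ccc(-n2nc(-c3ccc4ccccc4c3)nc2N2C(=O)COC23C=CC(=O)C=C3)cc1`: 200 nM
- compound 2 `CC1CN(c2nc(-c3ccc4ccccc4c3)nn2-c2ccccc2)C2(C=CC(=O)C=C2)O1`: 260 nM
- compound 3 `COc1ccc(-n2nc(-c3ccc4ccccc4c3)nc2N2C(=O)C(C)OC23C=CC(=O)C=C3)cc1`: 140 nM
- compound 4 `O=C1C=CC2(C=C1)OCC(=O)N2c1nc(-c2ccc3ccccc3c2)nn1-c1ccc2ccccc2c1`: not yet measured

Compound 1, at 200 nM, lies within the scatter of both other measured compounds, so no rank can be read for it from these numbers.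

The change to compound 4 is naphthalen-2-yl in place of 4-methoxyphenyl on an aromatic nitrogen. Going by the values given here, no measured step changes the group at this place. Among the compounds with values here, the only single-place step is a 1.4-fold lower number from compound 1 to compound 3 (0.15 log units; within the scatter), with methyl in place of hydrogen on a saturated ring carbon. It is small but sits elsewhere in the molecule, so it offers only weak guidance. Compound 2 also lacks the 4-methoxyphenyl and differs in other places too, yet it gives 260 nM, which is within the scatter of compound 1. The data therefore give no direction for the change, and no shift beyond the scatter is expected in this assay, though the uncertainty is wide. The expected step is a 1.1-fold higher number from compound 1 to compound 4 (0.04 log units; within the scatter). For compound 4 the estimated value is 220 nM, with an expected range of 70 nM to 700 nM.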

Compound 4, half-maximal inhibitory concentration: 210 nM
Estimate against measurement, compound 4: 1.0-fold (0.02 log units) above, within the range that was stated.
By their numbers in this assay, from the lowest: compounds 3, 1, 4 and 2 (each within the scatter of the next).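

In this assay the group on the aromatic nitrogen now has a direct single-place reading: the step is a 1.1-fold higher number from compound 1 to compound 4 (0.02 log units; within the scatter), with naphthalen-2-yl in place of 4-methoxyphenyl. Within this pair, the place takes the larger group, with its second six-membered aromatic ring and more heavy atoms, and the loss of the hydrogen-bond acceptor of 4-methoxyphenyl, without a shift beyond the scatter. No measurement is available that would explain this result.

On these data alone, the two groups compared here are both aromatic and carry no net charge, so it remains open whether the number would hold with a plain methyl, a longer alkyl chain or a group bearing an amine or a carboxylic acid on this nitrogen. As far as these compounds go, it is also open whether methyl on the saturated ring carbon, the change in the step of a 1.4-fold lower number from compound 1 to compound 3 (0.15 log units; within the scatter), would give a similar reading when combined with naphthalen-2-yl on the aromatic nitrogen.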